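The compounds below may be only part of what the source reports. "The series", "measured", "known", "first", "only" and "open" are said of these compounds alone.

Compound 1 `O=C(N/N=C/c1ccc([N+](=O)[O-])cc1)Nc1cc2c(Nc3ccc(F)c(Cl)c3)ncnc2cc1O[C@H]1CCOC1` gives 33500 nM in a functional assay on PC-3 cells (Homo sapiens) for cytotoxicity, read by MTT assay, with a stated time of 72 h; on this read-out lower numbers stand for stronger inhibition and higher numbers for weaker inhibition.
Compound 2 `O=C(N/N=C/c1ccc(O)cc1O)Nc1cc2c(Nc3ccc(F)c(Cl)c3)ncnc2cc1O[C@H]1CCOC1` gives 7540 nM.
Compound 3 `COc1cc2ncnc(Nc3ccc(F)c(Cl)c3)c2cc1NC(=O)N/N=C/c1ccc([N+](=O)[O-])cc1` gives 32400 nM.

Compound 3 holds the second highest of these three numbers: it lies next to compound 1, separated only by a 1.0-fold lower number from compound 1 to compound 3 (0.01 log units; within the scatter), and its number is well above that of compound 2. Compound 4 `CCN(CC)c1ccc(/C=N/NC(=O)Nc2cc3c(Nc4ccc(F)c(Cl)c4)ncnc3cc2OC)c(O)c1` is the unmeasured partner of compound 3; the change is 4-(diethylamino)-2-hydroxyphenyl in place of 4-nitrophenyl on a carbon with a double bond to nitrogen. For the measured compounds named here, two measured steps bear on it. The step of a 4.4-fold lower number from compound 1 to compound 2 (0.65 log units; beyond the scatter) shows that replacing 4-nitrophenyl at this same place with a hydroxyl-bearing ring lowered the number modestly, while a 1.0-fold lower number from compound 1 to compound 3 (0.01 log units; within the scatter) shows the methyl-for-oxolan-3-yl exchange on the core changed little, so a similar modest lowering is expected in this assay here. Compound 4 is therefore estimated at 9000 nM, likely between 3000 nM and 27000 nM. The expected step is a 3.6-fold lower number from compound 3 to compound 4 (0.56 log units; beyond the scatter).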

Compound 4, half-maximal inhibitory concentration: 34300 nM
Beside the measured number, compound 4's estimate is 3.8-fold (0.58 log units) below it, and the stated range ends below it.
By their numbers in this assay, from the lowest: compound 2; then compounds 3, 1 and 4 (each within the scatter of the next).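

In this assay, 4-(diethylamino)-2-hydroxyphenyl in place of 4-nitrophenyl on a carbon with a double bond to nitrogen gives a 1.1-fold higher number from compound 3 to compound 4 (0.02 log units; within the scatter) and so does not repeat the step seen with 2,4-dihydroxyphenyl on the other core (a 4.4-fold lower number from compound 1 to compound 2 (0.65 log units; beyond the scatter)). A hydroxyl-bearing ring at this place therefore does not by itself bring a lower number. Nothing measured here accounts for the difference between these two exchanges.
Open, from the compounds shown here alone, is whether 2,4-dihydroxyphenyl gives the same step with methyl on the core's oxygen, and whether a 4-(diethylamino)phenyl ring lacking the hydroxyl, or a ring bearing a carboxylic acid, changes the number at this place.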